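The source may report more compounds than this note shows. Statements on the series, on what has been measured and on what is new or still open speak of the compounds shown alone.

Measured so far in an ADME assay on MDCK cells (Canis lupus familiaris) for cytotoxicity, read by MTT assay, with a stated time of 48 h; on this read-out lower numbers stand for higher toxicity in this test and higher numbers for lower toxicity in this test:
compound 1 `Cc1cc(-c2ccccc2)n2nc(C(=O)Nc3ccccc3C(N)=O)nc2n1`: > 250000 nM.
compound 2 `Cc1cc(-c2ccccc2)n2nc(C(=O)Nc3nc4ccccc4s3)nc2n1`: > 250000 nM.
compound 3 `Cc1cc(-c2ccccc2)nc2nc(C(=O)Nc3ccccc3C(N)=O)nn12`: > 250000 nM.

For compound 1 the value > 250000 nM is a limit of the assay, not a number. For compound 2 the value > 250000 nM is likewise a limit. For compound 3 the value > 250000 nM is a limit as well. Compound 1 and compound 2 differ in one place: 1,3-benzothiazol-2-yl in place of 2-carbamoylphenyl on an amide-type nitrogen. The step that the two limits leave unreadable from compound 1 to compound 2 cannot be read, since both values sit at the limit of > 250000 nM in this assay, at which 3 of the 3 values shown sit. Compound 3 has the same atoms as compound 1 joined differently; the difference between the two cores is not broken down here.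

Compound 4 `Cc1cc(-c2ccccc2)nc2nc(C(=O)Nc3nc4ccccc4s3)nn12` has not yet been measured in this assay. It differs from compound 3 by 1,3-benzothiazol-2-yl in place of 2-carbamoylphenyl on an amide-type nitrogen, the same change, at the same place, as that from compound 1 to compound 2. The step from compound 3 to compound 4 is expected to be a step that the limit leaves unreadable from compound 3 to compound 4. This rests on compound 1, compound 2 and compound 3 all sitting at the limit of > 250000 nM in this assay, at which 3 of the 3 values shown sit. For compound 4 the estimate in this assay is therefore 300000 nM, most likely again reported only as a limit.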

Compound 4, half-maximal cytotoxic concentration: 233000 nM
For compound 4 the middle estimate is 1.3-fold (0.11 log units) above the measured one, within the range that was stated.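

In this assay, from the compounds shown here alone, the change gives an at least 1.0-fold lower number from compound 3 to compound 4 (0.03 log units; that floor lies within the scatter); that floor is all that can be read, and the true size of the step stays open. For compound 3, the value > 250000 nM is a limit and not a number. The same change on the core of compound 1 cannot be read either, so this result does not show that the change has the same size, or even the same direction, on both cores: the limit of > 250000 nM in this assay, at which 3 of the 4 values shown sit.

The compounds shown carry only 2-carbamoylphenyl and 1,3-benzothiazol-2-yl on the amide-type nitrogen, so what an amine, a carboxylic acid or a longer alkyl chain would give at that place stays open. Going by these compounds, it also stays open whether any such group would bring a readable number on the core of compound 1, which would allow a real comparison between the two cores.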